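Bromo to methylsulfanyl on the fused core

This account rests on a few compounds, and the source may have more. Where it says the series, first, only, none or still open, it means among the compounds named here.

Working notes on the series. Compound 1 `COc1cccc2cc(C(=O)O)cnc12` in a functional assay on the whole organism (strain Sprague-Dawley) for inhibition, with Rattus norvegicus as the target (a higher number here means that more compound is needed for the effect, a lower number that less compound is needed), gives 25 mg/kg. Compound 2 `O=c1c(-c2nn[nH]n2)c[nH]c2c(Br)cccc12` in this assay gives > 5 mg/kg, which is a limit of the assay and not a number. Going by the values given here, compound 2 therefore stands at the limit of > 5 mg/kg in this assay, at which 1 of the 2 values shown sits, with no step to another measured compound available. Compound 3 `CSc1cccc2c(=O)c(-c3nn[nH]n3)c[nH]c12` is not yet measured in this assay. The change from compound 2: methylsulfanyl in place of bromo on an aromatic carbon. Among the compounds with values here, no measured step covers this exchange, so for compound 3 a step that the limit leaves unreadable from compound 2 to compound 3 of moderate size is expected, with no clear direction beyond the scatter. Compound 3 is estimated at 10 mg/kg, within a range from 3 mg/kg to 40 mg/kg.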

Compound 3, minimum effective dose: 10 mg/kg
Compound 3: middle estimate and measured number agree at the digits printed; the range from low to high includes it.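

No step from compound 2 to compound 3 can be read in this assay, because compound 2 stands only at a limit of the assay: the limit of > 5 mg/kg in this assay, at which 1 of the 3 values shown sits.

The compounds shown leave open how far methylsulfanyl in place of bromo on an aromatic carbon shifts the minimum effective dose, or in which direction.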